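Methylating a Phenol Oxygen: Cytotoxicity in Two Amide Pairs

A few compounds are considered here, and "the series" means these few. Any claim that something is new, unique, unknown or untested is made for them only; others in the source may bear on it.

Compound 1 `COc1ccc(C(=O)Nc2ccc(Cl)cc2F)c(O)c1`: 32300 nM
Compound 2 `COc1ccc(C(=O)Nc2ccc(Cl)cc2F)c(OC)c1`: 13600 nM
Compound 3 `O=C(Nc1ccc(I)cc1F)c1ccccc1O`: 23300 nM

These three compounds were tested in an ADME assay on RAW264.7 cells (Mus musculus) for cytotoxicity, read by MTT assay, with a stated time of 24 h; on this read-out lower numbers stand for higher toxicity in this test and higher numbers for lower toxicity in this test. Compound 2 differs from compound 1 by one change, (methyl in place of hydrogen on an oxygen on an aromatic ring), and the step was a 2.4-fold lower number from compound 1 to compound 2 (0.38 log units; beyond the scatter). Compound 3 differs from compound 1 in more than one place; the difference between the two cores is not broken down here. Compound 4 `COc1ccccc1C(=O)Nc1ccc(I)cc1F` is not yet measured; it differs from compound 3 by methyl in place of hydrogen on an oxygen on an aromatic ring, the same change as that from compound 1 to compound 2, at a place described in identical words. The expected step is a 2.4-fold lower number from compound 3 to compound 4 (0.38 log units; beyond the scatter), resting on the measured 2.4-fold lower number from compound 1 to compound 2 (0.38 log units; beyond the scatter). Compound 4 is therefore expected to give 9700 nM in this assay, with an estimated range from 4800 nM to 19500 nM.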

Compound 4, half-maximal cytotoxic concentration: > 40000 nM
Compound 4 ended at the assay's limit (the forecaster's own chance of this, stated with the estimate: 5%); at least 4.1-fold (0.61 log units) between middle value and limit.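

In this assay compound 4 reached the limit of the test, > 40000 nM, which is a limit and not a number. Methyl in place of hydrogen on the oxygen gave an at least 1.7-fold higher number from compound 3 to compound 4 (0.23 log units; that floor lies within the scatter), so the step measured on one core did not carry over to the other: the same change on two cores in this assay, a 2.4-fold lower number (0.38 log units; beyond the scatter) from compound 1 to compound 2 and an at least 1.7-fold higher number (0.23 log units; that floor lies within the scatter) from compound 3 to compound 4, at least 4.0-fold (0.61 log units) apart, beyond the scatter of two such steps This rests on a single pair for each core, and it does not show why the two cores differ or how far compound 4 lies past the limit.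

The compounds shown leave open whether the gap follows the iodine of compound 3 or the chlorine and extra methoxy of compound 1. Going by these compounds, how an ethyl group or a longer chain on that oxygen would behave on either core also stays open.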